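The compounds below may be only part of what the source reports. "The series", "measured", "known", "first", "only" and "open" are said of these compounds alone.

Working notes on the quinolinone amide set.

Compound 1 `COc1ccc2c(C(=O)Nc3cc(F)cc(F)c3)cc(=O)[nH]c2c1` was run in a functional assay on KYSE-70 cells for antiproliferative activity against KYSE-70 cell line (Homo sapiens), read by MTT assay, with a stated time of 72 h (on this read-out lower numbers stand for stronger inhibition and higher numbers for weaker inhibition), and returns only the limit > 20000 nM, not a number. Compound 2 `COc1ccc2c(C(=O)Nc3cc(F)cc(F)c3)cc(=O)[nH]c2n1` likewise reaches only the limit > 20000 nM in this assay. Within the data shown here, compound 3 `O=C(Nc1cccc(F)c1)c1cc(=O)[nH]c2cc(-c3cccc(F)c3)ccc12` is the sole member with a measured number: in this assay compound 3 gives 12000 nM. Among the measured compounds shown here, compound 3 therefore stands as the only real value in the set, while the other two entries sit at the limit of > 20000 nM in this assay, at which 2 of the 3 values shown sit, so no measured step between any pair can be stated, and nothing about order among compounds 1, 2 and 3 can be claimed.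

Compound 4 `O=C(Nc1cccc(F)c1)c1cc(=O)[nH]c2cc(-c3ccc(F)c(CO)c3)ccc12` has not been measured. It departs from compound 3 in one place: 4-fluoro-3-(hydroxymethyl)phenyl in place of 3-fluorophenyl on an aromatic carbon. For the measured compounds named here, with no measured step available as a guide, the expectation rests on the single value of compound 3 and on the change itself; a move within the usual scatter or a modest gain in inhibition is expected, and the expected shift from compound 3 to compound 4 is a 1.5-fold lower number from compound 3 to compound 4 (0.18 log units; within the scatter). Compound 4 is accordingly estimated at 8000 nM in this assay, with an expected range from 3000 nM to 25000 nM.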

Compound 4, half-maximal inhibitory concentration: > 20000 nM
Compound 4 gave a limit, no number; the forecaster's own chance of this, stated with the estimate: 20%; middle value at least 2.5-fold (0.39 log units) from the limit.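

In this assay, among these compounds, putting 4-fluoro-3-(hydroxymethyl)phenyl in place of 3-fluorophenyl gives an at least 1.6-fold higher number from compound 3 to compound 4 (0.22 log units; that floor lies within the scatter), the first step between two compounds that differ in one place. This position on the aromatic carbon, meta to a fused ring and para to a fused ring, thus shows no gain in inhibition from this change, although the entering group brings 1 hydrogen-bond donor and 1 hydrogen-bond acceptor that 3-fluorophenyl lacks. Only the floor of the step is known, and its full size cannot be read because compound 4 ends at a limit of the assay rather than at a number: the limit of > 20000 nM in this assay, at which 3 of the 4 values shown sit.

As far as these compounds go, whether the step belongs to the hydroxymethyl or to the different place of the fluorine stays open, as the two change together between these compounds. Also open, from the compounds shown here alone, is how an aminomethyl group or a carboxylic acid would read in place of the hydroxymethyl, and whether any group on this aromatic carbon can give a number clearly lower than that of compound 3.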